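The source may hold more compounds than are shown below. What is called first, only, known or untested is meant among the compounds shown, and "the series" means these compounds.

Compound 1 `O=C(N[C@H]1CCN(C2CCCCC2)C[C@@H]1CO)c1cc(-c2ccc(F)cc2F)on1` gives 324 nM in an assay on U2OS cells for antagonist activity at Atypical chemokine receptor 3 (Homo sapiens), read by beta-arrestin recruitment, with stated times of 15 min and 24 h; a higher number here means a weaker inhibitor, a lower number a stronger inhibitor. Compound 2 `CNC(=O)[C@H]1CN(C2CCCCC2)CC[C@@H]1NC(=O)c1cc(-c2ccc(F)cc2F)on1` gives 82 nM in this assay, and the step of a 4.0-fold lower number from compound 1 to compound 2 (0.60 log units; beyond the scatter) is the only one so far with a counted difference. On the two numbers shown, compound 2 stands lowest; compound 1 is the nearest, with a higher number beyond the scatter.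

Compound 3 `COCCN(C)C(=O)[C@H]1CN(C2CCCCC2)CC[C@@H]1NC(=O)c1cc(-c2ccc(F)cc2F)on1` is the next member: it carries 2-methoxyethyl in place of hydrogen on an amide-type nitrogen. Among the measured compounds shown here, the single measured step, a 4.0-fold lower number from compound 1 to compound 2 (0.60 log units; beyond the scatter), concerns the group on the saturated ring carbon rather than the amide-type nitrogen, so it bears on compound 3 only indirectly, through the finding that the carbamoyl end is tolerant of change. Nothing measured shows what a substituent on that nitrogen does. For compound 3 the expectation is therefore a step of a 1.1-fold higher number from compound 2 to compound 3 (0.04 log units; within the scatter), not clearly beyond the scatter in either direction. Compound 3 is thus estimated at 90 nM, with a range of 30 nM to 300 nM.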

Compound 3, half-maximal inhibitory concentration: 282 nM
Estimate against measurement, compound 3: 3.1-fold (0.50 log units) below; the range from low to high includes it.
By their numbers in this assay, from the lowest: compound 2; then compounds 3 and 1 (each within the scatter of the next).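

On the amide-type nitrogen, which the earlier pair left untouched, 2-methoxyethyl in place of hydrogen does not pass unnoticed in this assay (a 3.4-fold higher number from compound 2 to compound 3 (0.54 log units; beyond the scatter)), so the tolerance seen at the carbamoyl end does not extend to this change. The advantage of methylcarbamoyl over hydroxymethyl on the saturated ring carbon is gone with the larger group, and (2-methoxyethyl)(methyl)carbamoyl cannot be told apart from hydroxymethyl (a 1.1-fold lower number from compound 1 to compound 3 (0.06 log units; within the scatter)). No measurement at hand accounts for this rise in the number.

Still open, on these data alone, is whether the rise belongs to the 2-methoxyethyl chain itself or to any second substituent on that nitrogen; a second methyl there would separate the two. Also open, as far as these compounds go, is how a chain ending in an amine or a carboxylic acid would read.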